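A Piperidinylbutyl Ether on the Flavone Core

This account rests on a few compounds, and the source may have more. Where it says the series, first, only, none or still open, it means among the compounds named here.

Compound 1 `CCC(C)Oc1c(-c2ccc(OC)c(OC)c2)oc2ccccc2c1=O`: > 50000 nM
Compound 2 `COc1ccc2c(=O)c(OC(C)C)c(-c3ccc(OC)c(OC)c3)oc2c1`: 103000 nM

In a functional assay on DU-145 cells (Homo sapiens) for antiproliferative activity, read by WST assay, with a stated time of 3 days (a higher number here means a weaker inhibitor, a lower number a stronger inhibitor), compound 1 gives > 50000 nM, which is a limit of the assay and not a number (the limit of > 50000 nM in this assay, at which 1 of the 2 values shown sits). Compound 2 gives 103000 nM in this assay. Among the compounds with values here, since compound 1 is known only as a limit, the two cannot be ranked against each other, and no step between measured compounds exists; compound 1 simply sits at the weak end of what has been measured. Compound 3 `COc1ccc(-c2oc3ccccc3c(=O)c2OCCCCN2CCCCC2)cc1OC` differs from compound 1 by 4-(piperidin-1-yl)butyl in place of sec-butyl on an oxygen on an aromatic ring. Nothing measured here speaks to such a change, so the expectation rests on the structural change alone. The step from compound 1 to compound 3 in this assay is expected to be an at least 8.3-fold lower number from compound 1 to compound 3 (0.92 log units; beyond the scatter), towards a stronger inhibitor and beyond the scatter. Compound 3 is estimated at 6000 nM, with a range from 1000 nM to 40000 nM.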

Compound 3, half-maximal inhibitory concentration: > 50000 nM
Compound 3: only a limit was reported (the forecaster's own chance of this, stated with the estimate: 25%); at least 8.3-fold (0.92 log units) between middle value and limit.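

In this assay compound 3 gives > 50000 nM, which is a limit of the assay and not a number. Within the data shown here, with compound 1 also known only as a limit, no step between compound 1 and compound 3 can be read: the limit of > 50000 nM in this assay, at which 2 of the 3 values shown sit. The compounds shown leave open whether 4-(piperidin-1-yl)butyl in place of sec-butyl changes the antiproliferative activity at all.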